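A Chlorine Moves on One Aromatic Group

The source may hold more compounds than are shown below. What is called first, only, known or untested is meant among the compounds shown, and "the series" means these compounds.

In a functional assay on U-87MG ATCC cells for antiproliferative activity against U-87 MG (Homo sapiens), read by MTT assay, with a stated time of 48 h (a lower number here means a stronger inhibitor, a higher number a weaker inhibitor), compound 2 `Cc1nc(-c2ccc(Cl)cc2)sc1C(=O)CSc1nc(-c2cccc(Cl)c2)c(C#N)c(=O)[nH]1` gives 40100 nM. Compound 3 `Cc1nc(-c2ccccc2)sc1C(=O)CSc1nc(-c2cccc(Cl)c2)c(C#N)c(=O)[nH]1` gives 28200 nM, which lies within the scatter of compound 2. Compound 1 `COc1ccc(-c2nc(C)c(C(=O)CSc3nc(-c4ccc(OC)c(OC)c4)c(C#N)c(=O)[nH]3)s2)cc1` gives 12500 nM, a lower number than compound 2 by more than the scatter, but it differs in several groups at once.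

Compound 4 `Cc1nc(-c2ccc(Cl)cc2)sc1C(=O)CSc1nc(-c2ccc(Cl)cc2)c(C#N)c(=O)[nH]1` differs from compound 2 in one place, with 4-chlorophenyl in place of 3-chlorophenyl on an aromatic carbon. Going by the values given here, only one measured step changes a single group, and it gives limited guidance. That step, a 1.4-fold lower number from compound 2 to compound 3 (0.15 log units; within the scatter), replaces a chloro with hydrogen elsewhere in the molecule and stays within the scatter. Among the compounds with values here, no measured pair shows the chlorine moving on this group, so neither direction can be favoured with confidence. The expected change is small, an estimated 1.1-fold lower number from compound 2 to compound 4 (0.06 log units; within the scatter), which would not go beyond the scatter. For compound 4, the estimated value in this assay is 35000 nM, with an expected range from 17000 nM to 70000 nM.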

Compound 4, half-maximal inhibitory concentration: 53000 nM
Beside the measured number, compound 4's estimate is 1.5-fold (0.18 log units) below it; measured number inside the range.
By their numbers in this assay, from the lowest: compound 1; then compounds 3, 2 and 4 (each within the scatter of the next).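

Going by these compounds alone, compound 2 and compound 4 give the only measured step that changes this position alone: moving the chlorine from 3-chlorophenyl to 4-chlorophenyl gives a 1.3-fold higher number from compound 2 to compound 4 (0.12 log units; within the scatter) in this assay. On the carbon next to the ring nitrogen, the two chlorine placements therefore cannot be told apart in this assay. No measured information here bears on why the two numbers fall so close together.

As far as these compounds go, it remains open whether a different group on this phenyl ring, such as an amine or a carboxylic acid, or a chlorine in 2-chlorophenyl, would shift the number beyond the scatter. From the compounds shown here alone, it is also open whether the same chlorine move would read alike with the plain phenyl group that compound 3 carries at the other end of the molecule.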